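A few compounds are considered here, and "the series" means these few. Any claim that something is new, unique, unknown or untested is made for them only; others in the source may bear on it.

Three close relatives built on one shared core have been tested in an ADME assay on NIH3T3 cells (Mus musculus) for cytotoxicity, read by MTT assay; a higher number here means a weaker inhibitor, a lower number a stronger inhibitor. Compound 1 `N#Cc1c(-c2ccc(Cl)cc2)c(C#N)c(=O)n(/N=C/c2cn(-c3ccccc3)nc2-c2ccccc2)c1N` gives 64 ug/mL. Compound 2 `N#Cc1c(-c2cccc(F)c2)c(C#N)c(=O)n(/N=C/c2cn(-c3ccccc3)nc2-c2ccccc2)c1N` gives 154 ug/mL, and compound 3 `Cc1ccc(-c2c(C#N)c(N)n(/N=C/c3cn(-c4ccccc4)nc3-c3ccccc3)c(=O)c2C#N)cc1` gives 98 ug/mL. Among these three numbers compound 3 stands second highest; its nearest neighbour is compound 1, and that gap, a 1.5-fold higher number from compound 1 to compound 3 (0.19 log units; within the scatter), lies within the scatter. The widest spread in the set, a 2.4-fold higher number from compound 1 to compound 2 (0.38 log units; beyond the scatter), is only modest, and a 1.6-fold lower number from compound 2 to compound 3 (0.20 log units; within the scatter) again sits within the scatter. So far the three numbers barely separate from one another.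

Compound 4 `N#Cc1c(-c2ccc(Br)cc2)c(C#N)c(=O)n(/N=C/c2cn(-c3ccccc3)nc2-c2ccccc2)c1N` has not yet been measured. It differs from compound 3 by bromo in place of methyl on an aromatic carbon. For the measured compounds named here, the measured step that bears most directly on this change is the one from compound 1 to compound 3, where chloro gave way to methyl at that aromatic carbon without moving the number beyond the scatter, a 1.5-fold higher number from compound 1 to compound 3 (0.19 log units; within the scatter). Putting bromo where methyl stood is in effect the reverse kind of exchange, so the expectation in this assay is a small shift at most, if anything toward a lower number, a 1.3-fold lower number from compound 3 to compound 4 (0.12 log units; within the scatter). Compound 4 is therefore estimated at 75 ug/mL, with a range from 40 ug/mL to 140 ug/mL.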

Compound 4, half-maximal inhibitory concentration: > 200 ug/mL
Compound 4 ended at the assay's limit; the forecaster's own chance of this, stated with the estimate: 5%; middle value at least 2.6-fold (0.42 log units) away from the limit.
By their numbers in this assay, from the lowest: compounds 1, 3 and 2 (each within the scatter of the next, the first and the last beyond it). At a limit, above all of these: compound 4.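

The earlier compounds shown here gave no sign that this aromatic carbon, para to a large group, was sensitive to its substituent, since chloro and methyl there stayed within the scatter of each other. Bromo changes that picture: in this assay there is an at least 3.1-fold higher number from compound 1 to compound 4 (0.49 log units; beyond the scatter), so two halogens at the same place can be told apart, even though methyl and chloro could not. The other two floors are less telling, with an at least 2.0-fold higher number from compound 3 to compound 4 (0.30 log units; that floor lies within the scatter) and an at least 1.2-fold higher number from compound 2 to compound 4 (0.11 log units; that floor lies within the scatter), so neither comparison separates the compounds yet, although the real gaps could be larger. Compound 4 gives > 200 ug/mL, which is a limit of the assay and not a number, so the full size of all three steps stays unknown; it is the only such value in the set: the limit of > 200 ug/mL in this assay, at which 1 of the 4 values shown sits.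

What the compounds shown leave open is how far the number for 4-bromophenyl lies past that limit, and whether the trend from chloro to bromo would carry on to iodo. Nor do they say how an amine, a carboxylic acid or a longer chain at this carbon would behave, or whether bromo at the position held by fluoro in compound 2 would give a similar result.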